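The source may report more compounds than this note shows. Statements on the series, on what has been measured and on what is new or still open speak of the compounds shown alone.

Working notes on the series in a functional assay on the whole organism (strain Wistar) for inhibition, with Rattus norvegicus as the target, read by paw edema, with stated times of 60 min and 3 h, at a dose of 100 mg/kg by the oral route; on this read-out higher numbers stand for more inhibition at the one dose given (going by the name of the read-out) and lower numbers for less inhibition. Compound 1 `COc1cc2c(cc1OC)C(CC(N)=O)CC2` gives 30.4% and compound 2 `CCCNC(=O)CC1CCc2cc(OC)c(OC)cc21` gives 29%; the step of a number 1.4 percentage points lower from compound 1 to compound 2 (within the scatter) is within the scatter, so compound 2 stands at the lower of two numbers without any real separation from compound 1. The next compound, compound 3 `COc1cc2c(cc1OC)C(CC(=O)NC(C)(C)C)CC2`, changes the same position again: tert-butyl in place of propyl on an amide-type nitrogen. Among the compounds with values here, the only measured step that bears on a substituent on this amide-type nitrogen is a number 1.4 percentage points lower from compound 1 to compound 2 (within the scatter), which did not move the read-out beyond the scatter, and nothing measured here shows a branched group at that position. On that basis no step beyond the scatter is expected; the step of no change at the digits printed from compound 2 to compound 3 (within the scatter) is the estimated change. Compound 3 is therefore expected to give 29%, with a range from 16% to 42%.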

Compound 3, a percentage reported as inhibition, in the whole organism at one dose (the size of the read-out at that dose, not a potency): 33.3%
Beside the measured number, compound 3's estimate is 4.3 percentage points below it, and the stated range covers the measured number.
By their numbers in this assay, from the lowest: compounds 2, 1 and 3 (each within the scatter of the next).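

With tert-butyl on the amide-type nitrogen, a branched group is now on record at this position: tert-butyl in place of propyl gives a number 4.3 percentage points higher from compound 2 to compound 3 (within the scatter) and tert-butyl in place of hydrogen gives a number 2.9 percentage points higher from compound 1 to compound 3 (within the scatter) with the core unchanged. In this assay neither propyl nor tert-butyl on this nitrogen separates from compound 1, so hydrogen, a straight chain and a branched chain all sit within the scatter of one another at this single dose. Nothing at hand explains this flat read-out.

As far as these compounds go, whether a longer chain such as octyl or a ring-bearing group such as benzyl on this nitrogen would stay within that scatter remains open. Also open, from the compounds shown here alone, is whether a carboxylic acid in place of the amide would leave the read-out at the same level.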